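Sulfonyl aryl variation, outlook for compound 4

This account rests on a few compounds, and the source may have more. Where it says the series, first, only, none or still open, it means among the compounds named here.

Measured so far in an assay on isolated protein for displacement of a labelled ligand from metabotropic glutamate receptor 5 (Homo sapiens), with a stated time of 60 min, tested at 1 uM; a higher number here means more inhibition at the concentration tested (going by the name of the read-out), a lower number less inhibition:
compound 1 `Cc1ccc(S(=O)(=O)c2cnc3ccc(Cl)cc3c2N2CCC(C)CC2)cc1F` gives 68%
compound 2 `COc1cccc(S(=O)(=O)c2cnc3ccc(Cl)cc3c2N2CCC(C)CC2)c1` gives 87%
compound 3 `Cc1ccc(S(=O)(=O)c2cnc3ccc(Cl)cc3c2N2CCC(C)CC2)cc1` gives 95%

Compound 3 stands highest of the three numbers, but compound 2 sits within the scatter of it (a number 8 percentage points higher from compound 2 to compound 3 (within the scatter)), so only compound 1 is clearly separated (a number 27 percentage points higher from compound 1 to compound 3 (beyond the scatter)). Compound 4 `Cc1ccc(S(=O)(=O)c2cnc3ccc(Cl)cc3c2N2CCC(C)CC2)cc1Cl` differs from compound 3 by chloro in place of hydrogen on an aromatic carbon.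

The step that bears on this is the one in which fluoro gave way to hydrogen on that same aromatic carbon, a number 27 percentage points higher from compound 1 to compound 3 (beyond the scatter). Chloro is a different halogen and no chloro-bearing analogue has been measured, so the reverse direction is expected but its size is uncertain. Compound 4 is expected to drop modestly, a step of a number 17 percentage points lower from compound 3 to compound 4 (beyond the scatter). The estimate for compound 4 is 78%, with a range of 55% to 95%.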

Compound 4, a percentage reported as inhibition, at one concentration (the size of the read-out at that concentration, not a potency): 81%
Compound 4: the middle estimate sits 3 percentage points below what was measured; the measured number falls inside the stated range.
By their numbers in this assay, from the lowest: compound 1; then compounds 4, 2 and 3 (each within the scatter of the next, the first and the last beyond it).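

In this assay, chloro on this aromatic carbon, ortho to a methyl group, also costs inhibition, as fluoro did: a number 14 percentage points lower from compound 3 to compound 4 (beyond the scatter). The two halogens are not interchangeable, with a number 13 percentage points higher from compound 1 to compound 4 (beyond the scatter), so the loss depends on which halogen enters. The 3-chloro-4-methylphenyl group stays within the scatter of the 3-methoxyphenyl group, a number 6 percentage points lower from compound 2 to compound 4 (within the scatter).

Nothing available explains the difference between the halogens. Open, as far as these compounds go, is whether bromo, or a nitrile, on this carbon would continue the trend from fluoro to chloro or break it.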